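Pyrazole substitution pattern and a predicted gain in potency

The source may hold more compounds than are shown below. What is called first, only, known or untested is meant among the compounds shown, and "the series" means these compounds.

Measured compounds and their values in an assay on cells for positive allosteric modulation of Cystic fibrosis transmembrane conductance regulator variant F508del (Homo sapiens), with stated times of 10 min and 7 s, in the presence of a further agent that is not named here; a higher number here means that more compound is needed for the effect, a lower number that less compound is needed:
compound 1 `CC1(C)Cc2c(sc(NC(=O)c3nnc[nH]3)c2C(N)=O)C(C)(C)O1`: 467 nM
compound 2 `CC1(C)Cc2c(sc(NC(=O)c3cn[nH]c3)c2C(N)=O)C(C)(C)O1`: 125 nM
compound 3 `Cc1cn[nH]c1C(=O)Nc1sc2c(c1C(N)=O)CC(C)(C)OC2(C)C`: 2 nM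

Compound 2 stands second highest of the three numbers in this assay. Its nearest neighbour is compound 1, a step of a 3.7-fold lower number from compound 1 to compound 2 (0.57 log units; beyond the scatter) away, while compound 3 lies far below it, by a 63-fold lower number from compound 2 to compound 3 (1.80 log units; beyond the scatter).

Compound 4 `Cc1cc(C(=O)Nc2sc3c(c2C(N)=O)CC(C)(C)OC3(C)C)[nH]n1` is the untested partner of compound 2. Their difference is 3-methyl-1H-pyrazol-5-yl in place of 1H-pyrazol-4-yl on a carbonyl carbon. Among the compounds with values here, the one measured step that speaks to this change is a 63-fold lower number from compound 2 to compound 3 (1.80 log units; beyond the scatter), where the ring attachment moved in the same way and a methyl was added, though at a different position of the ring. That step was large; the step of a 230-fold lower number from compound 1 to compound 3 (2.37 log units; beyond the scatter) points the same way. The methyl now sits elsewhere. A somewhat smaller gain is expected. Compound 4 is therefore estimated at 20 nM, with a range from 4 nM to 100 nM, a step of a 6.3-fold lower number from compound 2 to compound 4 (0.80 log units; beyond the scatter) expected from compound 2.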

Compound 4, half-maximal effective concentration: 13 nM
For compound 4 the middle estimate is 1.5-fold (0.19 log units) above the measured one, within the range that was stated.
By their numbers in this assay, from the lowest: compound 3; then compound 4; then compound 2; then compound 1.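

A methyl on the ring does not have to sit where compound 3 carries it for the number to fall: the 3-methyl-1H-pyrazol-5-yl group still gives a 9.6-fold lower number from compound 2 to compound 4 (0.98 log units; beyond the scatter), and against the triazole it gives a 36-fold lower number from compound 1 to compound 4 (1.56 log units; beyond the scatter). The place of the methyl also counts on its own, since moving it within the same 5-yl ring gives a 6.5-fold higher number from compound 3 to compound 4 (0.81 log units; beyond the scatter). Of the groups shown on this carbonyl carbon, the 4-methyl-1H-pyrazol-5-yl group of compound 3 therefore remains clearly the best.

Going by these compounds, how much of the fall from compound 2 belongs to the changed ring attachment and how much to the methyl stays open, as does the outcome with a larger group such as ethyl or with an amine in the methyl's place. Nothing given here explains these differences.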